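The compounds below may be only part of what the source reports. "The series", "measured", "known", "first", "only" and "open" are said of these compounds alone.

Working notes on the series.

Compound 1 `CNCC(=O)Nc1cc(OC)ccc1C(=O)c1cc(OC)c(OC)c(OC)c1` is the reference. In a functional assay on A2780 cells (Homo sapiens) for antiproliferative activity, read by MTT assay, with a stated time of 48 h (a lower number here means a stronger inhibitor, a higher number a weaker inhibitor), compound 1 gives 580 nM. Compound 2 `CCNCC(=O)Nc1cc(OC)ccc1C(=O)c1cc(OC)c(OC)c(OC)c1` carries the change methyl in place of hydrogen on a saturated chain carbon bound to an amine nitrogen on the core of compound 1; in this assay compound 2 gives 950 nM, and the step of a 1.6-fold higher number from compound 1 to compound 2 (0.21 log units; within the scatter) is small. The two values of compound 1 and compound 2 are therefore not to be read as an order.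

Compound 3 `C=C(c1ccc(OC)cc1NC(=O)CNC)c1ccc(OC)c2c1OC(C)(C)C=C2` has a different core; the difference between the two cores is not broken down here. In this assay compound 3 gives 210 nM, the lowest number of the three measured, with compound 1 nearest and compound 2 furthest, both beyond the scatter.

Compound 4 `C=C(c1ccc(OC)cc1NC(=O)CNCC)c1ccc(OC)c2c1OC(C)(C)C=C2` is not yet measured. It differs from compound 3 by methyl in place of hydrogen on a saturated chain carbon bound to an amine nitrogen, the same change that was made from compound 1 to compound 2, at the same place. Within the data shown here, with only that one earlier pair to go on, a step of about the same size as a 1.6-fold higher number from compound 1 to compound 2 (0.21 log units; within the scatter) is expected, which rests on compound 1 and compound 2 alone. The step from compound 3 to compound 4 in this assay is thus expected to read a 1.6-fold higher number from compound 3 to compound 4 (0.21 log units; within the scatter). For compound 4 an estimate of 340 nM follows, with a likely range from 150 nM to 750 nM.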

Compound 4, half-maximal inhibitory concentration: 1030 nM
Estimate against measurement, compound 4: 3.0-fold (0.48 log units) below, and the stated range ends below it.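

In this assay, methyl in place of hydrogen on a saturated chain carbon bound to an amine nitrogen gives a 4.9-fold higher number from compound 3 to compound 4 (0.69 log units; beyond the scatter), so on the core of compound 3 this change comes with a clear rise in the number. The step measured on the core of compound 1 therefore did not carry over in size to the core of compound 3: the same change on two cores in this assay, a 1.6-fold higher number (0.21 log units; within the scatter) from compound 1 to compound 2 and a 4.9-fold higher number (0.69 log units; beyond the scatter) from compound 3 to compound 4, 3.0-fold (0.48 log units) apart, beyond the scatter of two such steps. This rests on two pairs in one assay; it does not show what in the two cores separates the steps or how the change would read on a further core, and with the earlier step within the scatter, it does not establish a shared direction.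

The compounds shown leave open how a primary amine in place of the methylamino group would read on each core. They also leave open whether a longer chain, such as propyl in place of ethyl, would widen or narrow the gap between the two cores.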